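This account rests on a few compounds, and the source may have more. Where it says the series, first, only, none or still open, it means among the compounds named here.

Measured so far:
Compound 1 `CCc1cc(C)c(Oc2nc(C)cc(OC(CC)CC)c2C)c(C)c1` gives 55% in a functional assay on the whole organism for displacement of a labelled ligand, with Rattus norvegicus as the target, at a dose of 3.2 mg/kg by the subcutaneous route; on this read-out higher numbers stand for more inhibition at the one dose given (going by the name of the read-out) and lower numbers for less inhibition.
Compound 2 `CCCc1cc(C)c(Oc2nc(C)cc(OC(CC)CC)c2C)c(C)c1` gives 42% in this assay.

Going by the values given here, compound 2 stands lowest of the two numbers; its only neighbour is compound 1, and the step of a number 13 percentage points lower from compound 1 to compound 2 (beyond the scatter) lies beyond the scatter. Compound 3 `CCC(CC)Oc1cc(C)nc(Oc2c(C)cc(I)cc2C)c1C` is not yet measured. It differs from compound 2 by iodo in place of propyl on an aromatic carbon. Among the compounds with values here, the one measured step altered a saturated chain rather than an aromatic substituent, so no measured step bears directly on this change. For compound 3 the expected step is therefore a number 6 percentage points higher from compound 2 to compound 3 (within the scatter), near the scatter. The estimate for compound 3 is 48%, with a range from 25% to 72%.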

Compound 3, a percentage reported as inhibition, in the whole organism at one dose (the size of the read-out at that dose, not a potency): 27%
Beside the measured number, compound 3's estimate is 21 percentage points above it, within the range that was stated.
By their numbers in this assay, from the lowest: compound 3; then compound 2; then compound 1.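

In this assay, iodo in place of propyl gives a number 15 percentage points lower from compound 2 to compound 3 (beyond the scatter), and iodo in place of ethyl gives a number 28 percentage points lower from compound 1 to compound 3 (beyond the scatter). So this position, para to a large group, responds not only to the length of a carbon chain: a single iodine atom here gives a lower number than either chain. Nothing measured here explains the drop. The compounds shown leave open how a methoxy group, a chlorine atom or an amine would compare at this position. They also leave open whether the loss belongs to iodine itself or to the missing carbon chain.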